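The compounds below may be only part of what the source reports. "The series", "measured", "known", "first", "only" and "open" are said of these compounds alone.

Working notes on the series. In a functional assay on MCF7 cells (Homo sapiens) for antiproliferative activity, read by sulforhodamine B assay, with a stated time of 72 h (a lower number here means a stronger inhibitor, a higher number a weaker inhibitor), compound 1 `Fc1ccc(COc2ccc(-c3cc(CN4CCN(Cc5ccc(C(F)(F)F)cc5)CC4)no3)cc2)cc1` gives 7900 nM and compound 2 `N#Cc1cccc(COc2ccc(-c3cc(CN4CCN(c5ccc(C(F)(F)F)cc5)CC4)no3)cc2)c1` gives 2000 nM; compound 2 thus carries the lower of the two numbers, and the gap to compound 1 lies beyond the usual scatter. Compound 3 `N#Cc1cccc(COc2ccc(-c3cc(CN4CCN(Cc5ccccc5F)CC4)no3)cc2)c1` is not yet measured in this assay. The change is 2-fluorobenzyl in place of 4-(trifluoromethyl)phenyl on an amine nitrogen in a ring. Going by the values given here, with no single-change pair measured, the step from compound 2 to compound 3 is expected to be modest and toward a weaker inhibitor, a 2.5-fold higher number from compound 2 to compound 3 (0.40 log units; beyond the scatter). Compound 3 is estimated at 5000 nM, with a range of 1500 nM to 16000 nM.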

Compound 3, half-maximal inhibitory concentration: 1400 nM
Estimate against measurement, compound 3: 3.6-fold (0.55 log units) above; measured number below the stated range.
By their numbers in this assay, from the lowest: compounds 3 and 2 (each within the scatter of the next); then compound 1.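

In this assay, going by these compounds alone, 2-fluorobenzyl in place of 4-(trifluoromethyl)phenyl on the amine nitrogen in the ring gives a 1.4-fold lower number from compound 2 to compound 3 (0.15 log units; within the scatter) and provides the first single-change pair. At this position, the two groups therefore cannot be told apart in this read-out, even though the trifluoromethyl group is gone. No available evidence bears on this result.

Still open, on these data alone, is whether a longer chain in place of 2-fluorobenzyl, or an amine or carboxylic acid on its ring, would move the number beyond the scatter. The separate contribution of the fluorine also remains unresolved.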